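Phenyl for Dichlorophenyl on Two Related Cores

The source may hold more compounds than are shown below. What is called first, only, known or untested is meant among the compounds shown, and "the series" means these compounds.

Compound 1 `Cc1nc(-c2ccccc2)sc1C(=O)CSc1nc(-c2ccc(Cl)c(Cl)c2)c(C#N)c(=O)[nH]1`: in a functional assay on U-87MG ATCC cells for antiproliferative activity against U-87 MG (Homo sapiens), read by MTT assay, with a stated time of 48 h, tested at 50 uM (on this read-out higher numbers stand for a weaker effect at the one concentration tested and lower numbers for a stronger effect), compound 1 gives 75.3%.
Compound 2 `Cc1nc(-c2ccccc2)sc1C(=O)CSc1nc(-c2ccccc2)c(C#N)c(=O)[nH]1`: in this assay compound 2 gives 77.5%.
Compound 3 `COc1ccc(-c2nc(C)c(C(=O)CSc3nc(-c4ccc(Cl)c(Cl)c4)c(C#N)c(=O)[nH]3)s2)cc1`: in this assay compound 3 gives 78.4%.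

Compound 4 `COc1ccc(-c2nc(C)c(C(=O)CSc3nc(-c4ccccc4)c(C#N)c(=O)[nH]3)s2)cc1` has not been measured. It differs from compound 3 by phenyl in place of 3,4-dichlorophenyl on an aromatic carbon. The same change, (phenyl in place of 3,4-dichlorophenyl on an aromatic carbon), occurs once more among these compounds, between measured ones, and there it gave a number 2.2 percentage points higher from compound 1 to compound 2 (within the scatter). The two cores differ by methoxy in place of hydrogen on an aromatic carbon, which gave a number 3.1 percentage points higher from compound 1 to compound 3 (within the scatter). The values of compound 2 and compound 3 lie close together, so among the three measured compounds no order can be read. Compound 4 is expected to show a step of about a number 2.1 percentage points higher from compound 3 to compound 4 (within the scatter), because the earlier step of a number 2.2 percentage points higher from compound 1 to compound 2 (within the scatter) lay within the scatter. Compound 4 is therefore estimated at 80.5%, between 72% and 89%.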

Compound 4, a percentage reported as activity, at one concentration (the size of the read-out at that concentration, not a potency): 72.5%
Beside the measured number, compound 4's estimate is 8 percentage points above it; low and high end bracket the measured number.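

On the core carrying methoxy, phenyl in place of 3,4-dichlorophenyl gave a number 5.9 percentage points lower from compound 3 to compound 4 (within the scatter) in this assay, and methoxy in place of hydrogen gave a number 5 percentage points lower from compound 2 to compound 4 (within the scatter). The phenyl change shows no difference between the two cores that can be told from the scatter: the same change on two cores in this assay, a number 2.2 percentage points higher (within the scatter) from compound 1 to compound 2 and a number 5.9 percentage points lower (within the scatter) from compound 3 to compound 4, 8.1 percentage points apart, within the scatter of two such steps. The same holds for the methoxy change, yet this does not show that either change carries a real effect from core to core, since each step lies within the scatter: the same change on two cores in this assay, a number 3.1 percentage points higher (within the scatter) from compound 1 to compound 3 and a number 5 percentage points lower (within the scatter) from compound 2 to compound 4, 8.1 percentage points apart, within the scatter of two such steps.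

The compounds shown leave open whether an amine or a carboxylic acid in place of the methoxy group would move the number beyond the scatter. With one concentration read, the numbers speak only to a stronger or weaker effect at that concentration.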